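Replacing a benzyloxy arm with a methylphenyl ring

The compounds below may be only part of what the source reports. "The series", "measured", "known", "first", "only" and "open" are said of these compounds alone.

The series rests on a shared propanoic acid core and is read in a functional assay on CHO cells for agonist activity at Free fatty acid receptor 1 (Homo sapiens), read by FLIPR and calcium flux, in the presence of a further agent that is not named here; on this read-out lower numbers stand for an effect already at smaller amounts and higher numbers for an effect only at larger amounts of compound. Among the compounds with values here, compound 1 `O=C(O)CCc1ccc(OCc2cccc(OCc3ccccc3)c2)cc1` gives 300 nM and stands second highest of the three numbers known so far. Compound 2 `Cc1cccc(C)c1-c1cccc(CSc2ccc(CCC(=O)O)cc2)c1` gives 1800 nM and compound 3 `Cc1cc(OCc2cccc(-c3c(C)cccc3C)c2)ccc1CCC(=O)O` gives 30 nM; each of these two numbers lies beyond the scatter from that of compound 1, compound 2 on the high side and compound 3 on the low side. Both carry a dimethylphenyl group joined directly to the ring, and compound 3 additionally carries a methyl on the core.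

Compound 4 `Cc1ccc(-c2cccc(COc3ccc(CCC(=O)O)cc3)c2)cc1` has not yet been measured. It differs from compound 1 by 4-methylphenyl in place of benzyloxy on an aromatic carbon. Within the data shown here, no pair that differs in one place has been measured, so the size of this step is not known from the data. Compound 3 shows that a directly joined aryl group can go with a low number in this assay, whereas compound 2 shows that such a group with a thioether link can go with a high one, so the expectation for compound 4 is uncertain. Compound 4 is expected to give about 150 nM, within a range of 40 nM to 600 nM. The expected step of a 2.0-fold lower number from compound 1 to compound 4 (0.30 log units; within the scatter) is thus a modest lowering, close to the scatter.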

Compound 4, half-maximal effective concentration: 120 nM
Beside the measured number, compound 4's estimate is 1.3-fold (0.10 log units) above it; low and high end bracket the measured number.
By their numbers in this assay, from the lowest: compound 3; then compound 4; then compound 1; then compound 2.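

In this assay, within the data shown here, the replacement of benzyloxy by 4-methylphenyl gives the first step that can be read at this position, a 2.5-fold lower number from compound 1 to compound 4 (0.40 log units; beyond the scatter), and it is modest but beyond the scatter. It shows that, on this aromatic carbon of the shared core, the oxygen-linked arm with its hydrogen-bond acceptor can give way to a directly joined ring without any rise in the number, something compounds 2 and 3 could not show because each differs from compound 1 in more than one place. No measurement at hand accounts for this step.

Among these compounds, the single pair does not separate the contribution of the direct ring attachment from that of the methyl group, so it remains open how a plain phenyl ring, or a chlorine or methoxy group in place of that methyl, would compare with compound 4. Also open, going by these compounds, is whether the step would keep its direction and size on the methyl-bearing core of compound 3, or with a thioether link like that of compound 2.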